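This account rests on a few compounds, and the source may have more. Where it says the series, first, only, none or still open, it means among the compounds named here.

Measured so far:
- compound 1, `Nc1ccccc1NC(=O)c1ccc(CSc2nccc(C(F)(F)F)n2)cc1`: 970 nM
- compound 2, `Cc1cc(C)cc(SCc2ccc(C(=O)Nc3ccccc3N)cc2)c1`: 2890 nM

In a functional assay on A549 cells (Homo sapiens) for antiproliferative activity, read by CCK-8 assay, with a stated time of 72 h (on this read-out lower numbers stand for stronger inhibition and higher numbers for weaker inhibition), compound 1 gives 970 nM. In this assay compound 2 gives 2890 nM, the higher of the two numbers, with the gap to compound 1 beyond the scatter. Compound 3, `Nc1ccccc1NC(=O)c1ccc(CSCCc2ccccc2)cc1`, has not been measured in this assay. It differs from compound 2 only at the sulfur: phenethyl in place of 3,5-dimethylphenyl on a sulfur. Going by the values given here, no pair of measured compounds differs in a single place, so no measured step can guide the size of this change; the only comparison at hand is that compound 2 and compound 1, which carry different groups on the same sulfur, differ beyond the scatter. For compound 3 a step no larger than the scatter is expected, leaning slightly toward a lower number, with a 1.3-fold lower number from compound 2 to compound 3 (0.12 log units; within the scatter) as the expected step. Compound 3 is thus estimated at 2200 nM in this assay, within 700 nM to 7000 nM.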

Compound 3, half-maximal inhibitory concentration: 3250 nM
For compound 3 the middle estimate is 1.5-fold (0.17 log units) below the measured one; the measured number falls inside the stated range.
By their numbers in this assay, from the lowest: compound 1; then compounds 2 and 3 (each within the scatter of the next).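

In this assay, going by these compounds alone, phenethyl in place of 3,5-dimethylphenyl on a sulfur gives a 1.1-fold higher number from compound 2 to compound 3 (0.05 log units; within the scatter) and is the first step that changes a single place. At this position, a six-membered aromatic ring of carbon only bonded directly to the sulfur and the same kind of ring carried on the phenethyl chain cannot be told apart by this read-out. Nothing available accounts for this result.

This one step links two groups made of carbon only, so it leaves open how the position responds to an amine, a carboxylic acid or a hydroxyl group on the same sulfur. Going by these compounds, whether a longer chain or a benzyl group would also leave the number within the scatter remains open too.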